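Benzophenone ether amides: halogen swap on the benzoyl ring

The source may hold more compounds than are shown below. What is called first, only, known or untested is meant among the compounds shown, and "the series" means these compounds.

The series pairs a phenylthiazolyl acetamide with an aryloxy benzophenone. Compound 1 `Cc1ccc(C(=O)c2ccc(OCC(=O)Nc3nc(-c4ccccc4)cs3)c(C)c2)cc1` carries a methyl on the benzoyl ring; in a functional assay on DLA cells (Mus musculus) for cytotoxicity, read by MTT assay, with a stated time of 48 h (a lower number here means a stronger inhibitor, a higher number a weaker inhibitor), compound 1 gives 26400 nM. Compound 2 `Cc1cc(C(=O)c2ccc(F)cc2)ccc1OCC(=O)Nc1nc(-c2ccccc2)cs1` gives 33300 nM in this assay. Among the measured compounds shown here, the one step between them, a 1.3-fold higher number from compound 1 to compound 2 (0.10 log units; within the scatter), shows that exchanging the methyl for fluoro changes nothing that can be read beyond the noise. On the two numbers shown, compound 2 stands at 33300 nM with compound 1 at 26400 nM as its only neighbour, the gap within the scatter.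

Compound 3 `Cc1cc(C(=O)c2cccc(Br)c2)ccc1OCC(=O)Nc1nc(-c2ccccc2)cs1` is not yet measured. The change is 3-bromophenyl in place of 4-fluorophenyl on a carbonyl carbon. For the measured compounds named here, no measured step covers a bromo for fluoro exchange or a shift of the substituent within the benzoyl ring, so the only step that bears on it is a 1.3-fold higher number from compound 1 to compound 2 (0.10 log units; within the scatter), which was flat. On that basis a small step is expected in this assay, with no direction beyond the scatter, and a wide range. The expected step is a 1.1-fold lower number from compound 2 to compound 3 (0.05 log units; within the scatter). Compound 3 is estimated at 30000 nM, between 12000 nM and 75000 nM.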

Compound 3, half-maximal inhibitory concentration: 23800 nM
Beside the measured number, compound 3's estimate is 1.3-fold (0.10 log units) above it, within the range that was stated.
By their numbers in this assay, from the lowest: compounds 3, 1 and 2 (each within the scatter of the next).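

In this assay, the change on the carbonyl carbon from 4-fluorophenyl to 3-bromophenyl gives a 1.4-fold lower number from compound 2 to compound 3 (0.15 log units; within the scatter), and the change at the same place from 4-methylphenyl to 3-bromophenyl gives a 1.1-fold lower number from compound 1 to compound 3 (0.05 log units; within the scatter). The earlier pair covered only 4-methylphenyl and 4-fluorophenyl, whereas this result adds a bromine and a different substitution pattern on the phenyl group, and neither step can be read beyond the noise. The three groups tried on this carbonyl carbon therefore cannot be told apart by these numbers, and nothing available beyond the numbers themselves bears on why they lie so close.

Still open, on these data alone, is whether a group of another kind on this phenyl ring, such as an amine or a carboxylic acid, or a longer alkyl chain in place of the ring on the carbonyl carbon, would give a step beyond the scatter. The rest of the shared core is the same in compound 1, compound 2 and compound 3, so these values say nothing about how changes elsewhere in the core would read.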